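From Trifluoromethyl to Amino on a Shared Core

A few compounds are considered here, and "the series" means these few. Any claim that something is new, unique, unknown or untested is made for them only; others in the source may bear on it.

In a functional assay on HepG2 cells (Homo sapiens) for inhibition, read by MTT assay, with a stated time of 72 h (a higher number here means a weaker inhibitor, a lower number a stronger inhibitor), compound 3 `COc1cc(OC)c(C(=O)/C=C/c2ccc(C(F)(F)F)cc2)c(OC)c1` gives 9700 nM. This is the lowest of three numbers, although it lies within the scatter of compound 1 `COc1cc(OC)c(C(=O)/C=C/c2ccccc2OC)c(OC)c1` at 16300 nM. Compound 2 `COc1cc(OC)c(C(=O)/C=C/c2ccc(O)c(O)c2)c(OC)c1` gives 27500 nM. The gap between that number and the number of compound 3 lies beyond the scatter. Compound 4 `COc1cc(OC)c(C(=O)/C=C/c2ccc(N)cc2)c(OC)c1` follows from compound 3 by a single change, amino in place of trifluoromethyl on an aromatic carbon, para to a large group (amino in place of trifluoromethyl on an aromatic carbon). Among the compounds with values here, only one measured step bears on this, a 1.7-fold higher number from compound 1 to compound 2 (0.23 log units; within the scatter), and it involves different groups. No step beyond the scatter is therefore expected, with a slight rise at most. The expected result is a 1.2-fold higher number from compound 3 to compound 4 (0.09 log units; within the scatter). For compound 4, the estimated value is 12000 nM, within an expected range of 5000 nM to 28000 nM.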

Compound 4, half-maximal inhibitory concentration: 45200 nM
Compound 4: the middle estimate sits 3.8-fold (0.58 log units) below what was measured, outside the stated range (above it).
By their numbers in this assay, from the lowest: compounds 3, 1, 2 and 4 (each within the scatter of the next, the first and the last beyond it).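

Within the data shown here, with amino in place of trifluoromethyl on an aromatic carbon, para to a large group, this assay shows a 4.7-fold higher number from compound 3 to compound 4 (0.67 log units; beyond the scatter) and so gives the first single-place change here that clears the scatter. Among these compounds, replacing the aryl group elsewhere gives a 2.8-fold higher number from compound 1 to compound 4 (0.44 log units; beyond the scatter) but also a 1.6-fold higher number from compound 2 to compound 4 (0.22 log units; within the scatter) and thus separates compound 4 from only one of these two neighbours. No measurement offered here accounts for the rise. Going by these compounds, whether it follows from losing trifluoromethyl or gaining amino stays open, as does how a chlorine, a methyl or a nitrile would read at that place.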